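Swapping Anilino for Pyrrolidinyl on a Weakly Inhibiting Core

The source may hold more compounds than are shown below. What is called first, only, known or untested is meant among the compounds shown, and "the series" means these compounds.

Of the compounds shown here, three built on a shared core have been measured in a functional assay on MCF7 cells (Homo sapiens) for inhibition, read by sulforhodamine B assay; on this read-out higher numbers stand for weaker inhibition and lower numbers for stronger inhibition. Compound 1 `COc1cccc(NC2=CC(=O)c3c(nc4n3[C@H]3OC[C@@H](O)[C@H]3OC4)C2=O)c1` gives 3830 nM. Compound 2 `Cc1ccc(NC2=CC(=O)c3c(nc4n3[C@H]3OC[C@@H](O)[C@H]3OC4)C2=O)cc1C` gives 4950 nM. For compound 3 `O=C1C(Nc2ccccc2)=CC(=O)c2c1nc1n2[C@H]2OC[C@@H](O)[C@H]2OC1` this assay reports only a limit, > 4000 nM, so no number fixes its potency. Where compound 3 stands among the numbers shown therefore cannot be settled; all that is known is that it sits at the limit (the limit of > 4000 nM in this assay, at which 1 of the 3 values shown sits). The step of a 1.3-fold higher number from compound 1 to compound 2 (0.11 log units; within the scatter) was within the scatter, the step of an at least 1.0-fold higher number from compound 1 to compound 3 (0.01 log units; that floor lies within the scatter) is read only against the floor of that limit, and the step that the limit leaves unreadable from compound 2 to compound 3 cannot be read at all.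

Compound 4 `O=C1C(N2CCCC2)=CC(=O)c2c1nc1n2[C@H]2OC[C@@H](O)[C@H]2OC1` differs from compound 3 by pyrrolidin-1-yl in place of anilino on a double-bonded ring carbon. For the measured compounds named here, none of the measured steps touches the group on the amine nitrogen itself; all of them concern substituents on the phenyl ring, and none moved this assay beyond the scatter. The expectation is that compound 4 will remain in the same weakly inhibiting region. Compound 4 is estimated at 6000 nM, with a range from 2000 nM to 20000 nM. For compound 4 the expected step is a step that the limit leaves unreadable from compound 3 to compound 4, and a further limit rather than a number remains likely.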

Compound 4, half-maximal inhibitory concentration: > 16000 nM
Compound 4 gave a limit, no number (the forecaster's own chance of this, stated with the estimate: 60%); at least 2.6-fold (0.42 log units) between middle value and limit.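

Changing the group on the double-bonded ring carbon itself, from a substituted anilino to pyrrolidin-1-yl, gives an at least 3.2-fold higher number from compound 2 to compound 4 (0.50 log units; beyond the scatter) and an at least 4.1-fold higher number from compound 1 to compound 4 (0.62 log units; beyond the scatter) in this assay. Unlike the readable steps among compounds 1, 2 and 3, which concerned substituents on the phenyl ring and stayed within the scatter, these two steps lie beyond it, so this position responds to replacing the whole anilino group, in the direction of weaker inhibition. As far as these compounds go, compound 4 gives only a limit, > 16000 nM, so both steps are floors and their full size stays unknown.

The steps from compound 2 to compound 3 and from compound 3 to compound 4 cannot be read, which leaves the comparison with the unsubstituted anilino group of compound 3 unsettled. Pyrrolidin-1-yl also differs from anilino at once in its ring, which is non-aromatic, and in having no hydrogen-bond donor, and the compounds shown do not separate the two; cyclohexylamino, which keeps the amine hydrogen on a non-aromatic ring, and methylanilino, which keeps the phenyl ring without that hydrogen, would bear on this.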